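Swapping a chloro for a methyl on a fused thiazole core

The source may hold more compounds than are shown below. What is called first, only, known or untested is meant among the compounds shown, and "the series" means these compounds.

Measured compounds:
- Compound 1, `Cc1cn2c(/C=N/NC(=N)N)c(-c3ccncc3)nc2s1`, gives 17400 nM in a functional assay on prostate cells (Homo sapiens) for antiproliferative activity; a higher number here means a weaker inhibitor of growth, a lower number a stronger inhibitor of growth.
- Compound 2, `N=C(N)N/N=C/c1c(-c2ccccn2)nc2sc(Cl)cn12`, gives 9330 nM in this assay.

Going by the values given here, compound 2 holds the lowest of the two numbers so far in this assay, but its nearest neighbour, compound 1, sits within the scatter of it, so no order between the two can be claimed. The two compounds also differ in more than one place, so their values say nothing about any single change.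

Compound 3, `Cc1cn2c(/C=N/NC(=N)N)c(-c3ccccn3)nc2s1`, differs from compound 2 in one place only: methyl in place of chloro on an aromatic carbon. Among the compounds with values here, the exchanged groups are of similar size, and the data offer no step that isolates this change. Compound 1 also carries a methyl at this position and gives 17400 nM, which does not point to a large effect either way. For this reason a step of no size beyond the scatter is expected in this assay.

For compound 3 an estimated value of 12000 nM in this assay is expected, in a range from 5000 nM to 30000 nM. This amounts to an expected step of a 1.3-fold higher number from compound 2 to compound 3 (0.11 log units; within the scatter).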

Compound 3, concentration for 50% growth inhibition: 7940 nM
Compound 3: the middle estimate sits 1.5-fold (0.18 log units) above what was measured; the range from low to high includes it.
By their numbers in this assay, from the lowest: compounds 3, 2 and 1 (each within the scatter of the next, the first and the last beyond it).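

In this assay, going by these compounds alone, putting methyl in place of chloro on this aromatic carbon, next to the ring sulfur, gives (a 1.2-fold lower number from compound 2 to compound 3 (0.07 log units; within the scatter)), and this is the first pair to isolate that change: at this position, with pyridin-2-yl on the shared core, the two groups cannot be told apart in this assay. Compound 3 also gives a second single-place comparison. It keeps the methyl of compound 1 and differs only in carrying pyridin-2-yl in place of pyridin-4-yl, which gives (a 2.2-fold lower number from compound 1 to compound 3 (0.34 log units; beyond the scatter)), a modest step and the only one of the two beyond the scatter. Nothing in the data gives a reason for either step.

Going by these compounds, only chloro and methyl have been seen at this carbon, so it remains open whether an amine, a carboxylic acid or a longer chain there would leave the number just as unmoved. Chloro appears here only with pyridin-2-yl, so it also remains open whether the pyridine step would hold with chloro on the core, and how pyridin-3-yl or a plain phenyl ring would compare.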